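From benzylcarbamoyl to pyridin-3-yl on the shared core

A few compounds are considered here, and "the series" means these few. Any claim that something is new, unique, unknown or untested is made for them only; others in the source may bear on it.

Compound 1 `c1ccc(-c2nc3cccnc3n2C2CCCC2)cc1`: 3000 nM
Compound 2 `O=C(NCc1ccccc1)c1ccc(-c2nc3cccnc3n2C2CCCC2)cc1`: 620 nM
Compound 3 `Cc1cc(-c2nc3cccnc3n2C2CCCC2)cnc1F`: 70 nM

In a functional assay on MDA-MB-231 cells (Homo sapiens) for cytotoxicity, read by MTT assay, with a stated time of 24 h (a higher number here means a weaker inhibitor, a lower number a stronger inhibitor), compound 2 holds the second highest of the three numbers, with compound 1 higher and compound 3 lower. Compound 4 `c1cncc(-c2ccc(-c3nc4cccnc4n3C3CCCC3)cc2)c1` is still unmeasured and differs from compound 2 thus: pyridin-3-yl in place of benzylcarbamoyl on an aromatic carbon. Within the data shown here, one measured step bears on this change, a 4.8-fold lower number from compound 1 to compound 2 (0.68 log units; beyond the scatter), which introduced the benzylcarbamoyl now being replaced. Among the measured compounds shown here, compound 4 swaps that group for pyridin-3-yl instead of hydrogen, and no measured step shows this exchange. On these data alone, a step beyond the scatter is therefore not expected, and its direction stays open. The expected change is a 1.2-fold lower number from compound 2 to compound 4 (0.09 log units; within the scatter). For compound 4 the estimated value is 500 nM, with an expected range from 130 nM to 2000 nM.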

Compound 4, half-maximal inhibitory concentration: > 10000 nM
Compound 4 ended at the assay's limit (the forecaster's own chance of this, stated with the estimate: 5%); middle value at least 20-fold (1.30 log units) from the limit.
By their numbers in this assay, from the lowest: compound 3; then compound 2; then compound 1. At a limit, above all of these: compound 4.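

The value of compound 4 in this assay is a limit of the assay, not a number: the limit of > 10000 nM in this assay, at which 1 of the 4 values shown sits. On this aromatic carbon, pyridin-3-yl gives an at least 16-fold higher number from compound 2 to compound 4 (1.20 log units; beyond the scatter), and even against hydrogen it gives an at least 3.3-fold higher number from compound 1 to compound 4 (0.52 log units; beyond the scatter). The lower number that benzylcarbamoyl brought therefore does not extend to every aromatic ring placed here, and this exchange reverses the direction seen on adding benzylcarbamoyl.

The compounds shown leave open whether the amide or the benzyl ring of compound 2 accounts for its lower number. A plain carboxamide, a carboxylic acid or a phenyl ring at this place would help separate the two.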